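Swapping the Aryl Group on a Saturated Ring Carbon

The compounds below may be only part of what the source reports. "The series", "measured", "known", "first", "only" and "open" are said of these compounds alone.

Of the compounds shown here, three sharing one core have been measured in a functional assay on the whole organism (plasma, strain albino) for inhibition, with Rattus norvegicus as the target, with stated times of 1 h and 4 h, at a dose of 50 mg/kg by the oral route; a lower number here means a weaker effect, a higher number a stronger effect of the compound at the dose given. Compound 1 `COc1ccc(Cl)cc1C(=O)Nc1ccc(C2=NN(C)C(c3ccccc3[N+](=O)[O-])C2)cc1` gives 91.3%. Among the measured compounds shown here, compound 2 `COc1ccc(Cl)cc1C(=O)Nc1ccc(C2=NN(c3ccccc3)C(c3ccccc3[N+](=O)[O-])C2)cc1` gives 84.4%; the only change between these two is a number 6.9 percentage points lower from compound 1 to compound 2 (within the scatter). Compound 3 `COc1ccc(C2CC(c3ccc(NC(=O)c4cc(Cl)ccc4OC)cc3)=NN2)cc1` gives 83%, which lies within the scatter of both compound 2 and compound 1, so the three numbers cannot be told apart.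

Compound 4 `COc1ccc(Cl)cc1C(=O)Nc1ccc(C2=NNC(c3ccccc3[N+](=O)[O-])C2)cc1` has not yet been measured. It differs from compound 3 by one change: 2-nitrophenyl in place of 4-methoxyphenyl on a saturated ring carbon. For the measured compounds named here, no measured step touches this same saturated ring carbon; the one known step, from compound 1 to compound 2, concerns the ring nitrogen and stayed within the scatter. Compound 1 and compound 2, which both carry 2-nitrophenyl at this carbon, show values close to that of compound 3. No shift beyond the scatter is therefore expected, so the step of a number 3 percentage points higher from compound 3 to compound 4 (within the scatter) is estimated to be small. For compound 4 the expected value in this assay is 86%, within a range from 74% to 95%.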

Compound 4, a percentage reported as inhibition, in the whole organism at one dose (the size of the read-out at that dose, not a potency): 84.5%
Compound 4: the middle estimate sits 1.5 percentage points above what was measured; measured number inside the range.
By their numbers in this assay, from the lowest: compounds 3, 2, 4 and 1 (each within the scatter of the next).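

Putting 2-nitrophenyl in place of 4-methoxyphenyl on the saturated ring carbon gives a number 1.5 percentage points higher from compound 3 to compound 4 (within the scatter) in this assay, so these two aryl groups cannot be told apart at this position. With 2-nitrophenyl on that carbon, the ring nitrogen can carry hydrogen in place of phenyl, giving a number 0.1 percentage points higher from compound 2 to compound 4 (within the scatter), or hydrogen in place of methyl, giving a number 6.8 percentage points lower from compound 1 to compound 4 (within the scatter), so hydrogen, methyl and phenyl cannot be told apart there either. Nothing measured here offers an explanation for these close numbers.

From the compounds shown here alone, whether an amine or a carboxylic acid on the saturated ring carbon, or a longer chain on the ring nitrogen, would move the number beyond the scatter remains open. With only one dose shown, it is also open whether these compounds would separate at a smaller dose.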